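Alpha-Methyl Branching on the Propanoic Acid Chain

The compounds below may be only part of what the source reports. "The series", "measured", "known", "first", "only" and "open" are said of these compounds alone.

Compound 1 `COc1cc(-c2cccn(Cc3ccc(CCC(=O)O)cc3)c2=O)ccc1NC(=O)Nc1ccccc1C`: 0.501 nM
Compound 2 `Cc1ccccc1NC(=O)Nc1ccc(-c2cccn(Cc3ccc(CCC(=O)O)cc3)c2=O)cc1`: 2.51 nM

Among the compounds with values here, in an assay on Jurkat cells for inhibition of integrin alpha-4/beta-1 (Homo sapiens) (on this read-out lower numbers stand for stronger inhibition and higher numbers for weaker inhibition), compound 2 gives the higher of the two numbers, the only measured step being a 5.0-fold higher number from compound 1 to compound 2 (0.70 log units; beyond the scatter). Compound 3 `Cc1ccccc1NC(=O)Nc1ccc(-c2cccn(Cc3ccc([C@H](C)CC(=O)O)cc3)c2=O)cc1` differs from compound 2 by methyl in place of hydrogen on a saturated chain carbon bound to an aromatic carbon and a saturated chain carbon. Within the data shown here, no measured step touches this chain position, so the methoxy-to-hydrogen step gives no guide to its size or direction. With nothing bearing on it, the step is expected to stay within the scatter, as a 1.0-fold lower number from compound 2 to compound 3 (0.00 log units; within the scatter). Compound 3 is therefore estimated at 2.5 nM, with a range of 0.8 nM to 8 nM.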

Compound 3, inhibition constant: 1 nM
Beside the measured number, compound 3's estimate is 2.5-fold (0.40 log units) above it; low and high end bracket the measured number.
By their numbers in this assay, from the lowest: compounds 1 and 3 (each within the scatter of the next); then compound 2.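

Methyl in place of hydrogen on a saturated chain carbon bound to an aromatic carbon and a saturated chain carbon is more than tolerated in this assay, giving a 2.5-fold lower number from compound 2 to compound 3 (0.40 log units; beyond the scatter). Within the data shown here, this shows that the chain position, untouched by the earlier compounds, responds to branching, with 4-(1-(carboxymethyl)ethyl)phenyl giving the lower number than 4-(2-carboxyethyl)phenyl. Nothing at hand explains the step. Still open, as far as these compounds go, are how the opposite configuration at this carbon or an ethyl group there would read, and whether methoxy and this methyl would combine.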